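Methoxycarbonyl in place of hydroxymethyl: a stability note

The compounds below may be only part of what the source reports. "The series", "measured", "known", "first", "only" and "open" are said of these compounds alone.

In an in vitro ADME assay on microsomes from liver (Homo sapiens) for metabolic stability, tested at 1 uM (a higher number here means that the compound lasts longer, a lower number that the compound disappears faster), compound 3 `Cc1cc(CCC#N)cc(C)c1Oc1cc(Nc2ccc(C#N)cc2)c(N)cc1CO` gives 0.348 h. Compound 1 `Cc1cc(/C=C/C#N)cc(C)c1Oc1cc(Nc2ccc(C#N)cc2)c(N)cc1C(N)=O` gives 0.583 h, and the two values agree within the scatter. Compound 2 `Cc1cc(/C=C/C#N)cc(C)c1Oc1cc(Nc2ccc(C#N)cc2)c(N)cc1[N+](=O)[O-]` gives 0.797 h. The gap between compound 2 and compound 3 exceeds the scatter, and compound 3 has the lower number.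

Compound 4 `COC(=O)c1cc(N)c(Nc2ccc(C#N)cc2)cc1Oc1c(C)cc(CCC#N)cc1C` carries methoxycarbonyl in place of hydroxymethyl on an aromatic carbon, para to a (4-cyanophenyl)amino group: methoxycarbonyl in place of hydroxymethyl on an aromatic carbon.

For the measured compounds named here, the only measured step available as a guide is a 1.4-fold higher number from compound 1 to compound 2 (0.14 log units; within the scatter), with nitro in place of carbamoyl on an aromatic carbon. It stays within the scatter. Going by the values given here, the support is thin, since compound 1 and compound 2 also differ from compound 3 elsewhere in the structure, and no measured pair involves hydroxymethyl or methoxycarbonyl. With that single small step as the guide, only a modest upward move is expected in this assay, and the expected step is a 1.4-fold higher number from compound 3 to compound 4 (0.16 log units; within the scatter). Compound 4 is estimated at 0.5 h, with an expected range of 0.22 h to 1.1 h.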

Compound 4, half-life: 3.1 h
Estimate against measurement, compound 4: 6.2-fold (0.79 log units) below; measured number outside the range, above it.
By their numbers in this assay, from the lowest: compounds 3, 1 and 2 (each within the scatter of the next, the first and the last beyond it); then compound 4.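

In this assay, methoxycarbonyl in place of hydroxymethyl on this aromatic carbon, para to a (4-cyanophenyl)amino group, gives an 8.9-fold higher number from compound 3 to compound 4 (0.95 log units; beyond the scatter), with the rest of the structure unchanged. For the compounds shown here, the earlier single-place change, a 1.4-fold higher number from compound 1 to compound 2 (0.14 log units; within the scatter), stayed within the scatter, so this is the first sign that the group at this carbon can move the half-life well beyond it. No measurement in hand offers an explanation for the size of this step.

Resting on a single pair, the step cannot yet be generalised to other groups at this carbon or to other versions of the core. Going by these compounds, it remains open whether a carboxylic acid or ethoxycarbonyl here would keep the half-life near that of compound 4 or return it towards that of compound 3.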